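Ring methylation and potency in a small imidazoline series

This account rests on a few compounds, and the source may have more. Where it says the series, first, only, none or still open, it means among the compounds named here.

Measured in an in vitro functional assay on cells (Fibroblast) for agonist activity at Alpha-1A adrenergic receptor (Homo sapiens); a lower number here means that less compound is needed, a higher number that more compound is needed for the effect:
compound 1 `Cn1ncnc1-c1ccccc1NCC1=NCCN1` gives 2 nM
compound 2 `CCn1ncnc1-c1ccccc1NCC1=NCCN1` gives 1.26 nM
compound 3 `CC(C)n1ncnc1-c1ccccc1NCC1=NCCN1` gives 6.31 nM

Compound 1 stands second highest of the three numbers; compound 2 is nearest, with a 1.6-fold lower number from compound 1 to compound 2 (0.20 log units; within the scatter), and compound 3 is furthest, with a 3.2-fold higher number from compound 1 to compound 3 (0.50 log units; beyond the scatter). Compound 4 `Cc1nc(-c2ccccc2NCC2=NCCN2)n(C)n1` differs from compound 1 by methyl in place of hydrogen on an aromatic carbon. Going by the values given here, none of the measured steps touches that position: a 1.6-fold lower number from compound 1 to compound 2 (0.20 log units; within the scatter), a 3.2-fold higher number from compound 1 to compound 3 (0.50 log units; beyond the scatter) and a 5.0-fold higher number from compound 2 to compound 3 (0.70 log units; beyond the scatter) all vary the group on the aromatic nitrogen, and the whole series spans only a modest range in this assay . Among the compounds with values here, no measured step therefore bears directly on this change, and a step near or just beyond the scatter is expected, direction uncertain, leaning higher. For compound 4 a value of 3.5 nM is expected, within 1.2 nM to 12 nM, meaning an expected step of a 1.8-fold higher number from compound 1 to compound 4 (0.24 log units; within the scatter).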

Compound 4, half-maximal effective concentration: 1000 nM
Compound 4: the middle estimate sits 290-fold (2.46 log units) below what was measured, outside the stated range (above it).
By their numbers in this assay, from the lowest: compounds 2 and 1 (each within the scatter of the next); then compound 3; then compound 4.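

In this assay, the group on the ring nitrogen had moved the number only modestly, but the aromatic carbon between two ring nitrogen atoms is far more sensitive: methyl in place of hydrogen there gives a large step (a 500-fold higher number from compound 1 to compound 4 (2.70 log units; beyond the scatter)). One added heavy atom at this carbon thus outweighs every change among compound 1, compound 2 and compound 3. Nothing measured here accounts for the step.

From the compounds shown here alone, whether any group at this carbon has the same effect stays open, as an amine, a chlorine or a longer chain there would show. Also open, going by these compounds, is whether the methyl acts alike on the core of compound 2.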